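The source may hold more compounds than are shown below. What is called first, only, known or untested is meant among the compounds shown, and "the series" means these compounds.

Of the compounds shown here, three have been measured in a functional assay on CHO cells for antagonist activity at prostaglandin E2 receptor EP3 subtype (Homo sapiens), read by cAMP accumulation; a higher number here means a weaker inhibitor, a lower number a stronger inhibitor. Compound 1 `CCn1ncc2c(F)cc(-c3ccc(C(CC)(CC)c4nnc(C)[nH]4)c(=O)[nH]3)cc21` gives 90 nM in this assay. Compound 3 `CCC(CC)(c1nnc[nH]1)c1ccc(-c2ccc3cccc(F)c3c2)[nH]c1=O` gives 36 nM. Compound 2 `CC(C)C(c1ccc(-c2ccc3cccc(F)c3c2)[nH]c1=O)N1CCNC1=O` gives 28 nM, the lowest of the three numbers; its gap to compound 3 lies within the usual scatter, while its gap to compound 1 lies beyond it, so compound 2 and compound 3 cannot be ranked against each other on these data.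

Compound 4 `Cc1nc(C(c2ccc(-c3ccc4cccc(F)c4c3)[nH]c2=O)C(C)C)[nH]c1C` has not yet been measured. It differs from compound 2 in a single place: 4,5-dimethyl-1H-imidazol-2-yl in place of 2-oxoimidazolidin-1-yl on a saturated chain carbon bound to an aromatic carbon and a saturated chain carbon. Among the compounds with values here, no pair of measured compounds isolates this exchange, so the expectation rests on the level of the set as a whole. Compound 3, which gives 36 nM in this assay, carries an aromatic five-membered ring with one hydrogen-bond donor and one acceptor on the corresponding chain carbon and sits close to compound 2, which is taken as the best guide. The step that the estimate implies, a 1.4-fold higher number from compound 2 to compound 4 (0.15 log units; within the scatter), is expected to be small, toward a weaker inhibitor if anything, and not clearly beyond the scatter. Compound 4 is therefore estimated at 40 nM, with a range from 15 nM to 110 nM.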

Compound 4, half-maximal inhibitory concentration: 50 nM
Compound 4: the middle estimate sits 1.3-fold (0.10 log units) below what was measured, within the range that was stated.
By their numbers in this assay, from the lowest: compounds 2, 3, 4 and 1 (each within the scatter of the next, the first and the last beyond it).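

Within the data shown here, the exchange of 2-oxoimidazolidin-1-yl for 4,5-dimethyl-1H-imidazol-2-yl gives the first one-place comparison in this set: in this assay it produces a 1.8-fold higher number from compound 2 to compound 4 (0.25 log units; within the scatter). On this saturated chain carbon bound to an aromatic carbon and a saturated chain carbon, a non-aromatic ring carrying oxygen can therefore give way to a larger aromatic ring without oxygen, with no change that can be told from the scatter. The step holds for this one pair only, and both rings are five-membered with 2 hetero atoms and have the same hydrogen-bond donor and acceptor counts.

As far as these compounds go, it remains open what the two methyl groups of the new ring contribute, and whether a primary amine or a carboxylic acid on the same chain carbon would fit equally well. Nothing measured here gives a reason for the outcome.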